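This account rests on a few compounds, and the source may have more. Where it says the series, first, only, none or still open, it means among the compounds named here.

Three compounds share one core and differ only in the group carried on the nitrogen. Compound 1 `COc1ccc(CNc2ccc(-c3cnco3)c(OC)c2)cc1` gives 23900 nM in an ADME assay on Vero cells (Chlorocebus sabaeus) for cytotoxicity, read by MTT assay, with a stated time of 96 h; a lower number here means that less compound is tolerated, a higher number that more compound is tolerated. Compound 3 `COc1cc(NCc2cc(OC)c(OC)c(OC)c2)ccc1-c1cnco1` gives 41600 nM in this assay. Compound 2 `COc1cc(NCc2scnc2C)ccc1-c1cnco1` gives 73700 nM in this assay, the highest of the three numbers; its gap to compound 3 lies within the scatter, while its gap to compound 1 lies beyond it. Compound 4 `COc1cc(NCc2ccc(C)s2)ccc1-c1cnco1` differs from compound 2 by 5-methylthiophen-2-yl in place of 4-methyl-1,3-thiazol-5-yl on a saturated chain carbon bound to a nitrogen on an aromatic ring. For the measured compounds named here, no measured pair shows this change, so the step from compound 2 to compound 4 is expected to be small, a 1.3-fold lower number from compound 2 to compound 4 (0.13 log units; within the scatter), and not beyond the scatter. Compound 4 is therefore estimated at 55000 nM, within 25000 nM to 120000 nM.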

Compound 4, half-maximal cytotoxic concentration: 24700 nM
Estimate against measurement, compound 4: 2.2-fold (0.35 log units) above; the measured number lies below the stated range.
By their numbers in this assay, from the lowest: compounds 1, 4, 3 and 2 (each within the scatter of the next, the first and the last beyond it).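

In this assay, replacing 4-methyl-1,3-thiazol-5-yl with 5-methylthiophen-2-yl on a saturated chain carbon bound to a nitrogen on an aromatic ring gives a 3.0-fold lower number from compound 2 to compound 4 (0.47 log units; beyond the scatter). For the compounds shown here, this is the first single-place comparison here, and it shows that tolerance can shift with a change between two five-membered aromatic rings of equal heavy-atom count. Nothing measured here explains the shift. Still open, going by these compounds, is how this place would respond to a carboxylic acid, an amine or a longer chain.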